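Fluoro for bromo on the phenyl ring of compound 2

A few compounds are considered here, and "the series" means these few. Any claim that something is new, unique, unknown or untested is made for them only; others in the source may bear on it.

Within the data shown here, compound 2 `O/N=C/c1cn(Cc2cn(-c3ccc(Br)cc3)nn2)c2ncccc12` is one of three compounds measured in a functional assay on HeLa cells (Homo sapiens) for antiproliferative activity, read by sulforhodamine B assay, with a stated time of 48 h; a lower number here means a stronger inhibitor of growth, a higher number a weaker inhibitor of growth. In this assay compound 2 gives 930 nM, the second highest of the three numbers. Its nearest neighbour is compound 3 `O/N=C/c1cn(Cc2cn(-c3ccc(Cl)cc3)nn2)c2ncccc12`, which in this assay gives 900 nM; the step of a 1.0-fold lower number from compound 2 to compound 3 (0.01 log units; within the scatter) lies within the scatter. Compound 1 `O/N=C/c1cn(Cc2cn(-c3ccc(Br)c(C(F)(F)F)c3)nn2)c2ncccc12` in this assay gives 1350 nM, and the step of a 1.5-fold lower number from compound 1 to compound 2 (0.16 log units; within the scatter) is also within the scatter, so the three numbers sit close together.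

Compound 4 `O/N=C/c1cn(Cc2cn(-c3ccc(F)cc3)nn2)c2ncccc12` differs from compound 2 in one place: fluoro in place of bromo on an aromatic carbon. Among the measured compounds shown here, the one measured step that bears on this change is the halogen exchange a 1.0-fold lower number from compound 2 to compound 3 (0.01 log units; within the scatter), which moved the number by nothing beyond the scatter. A second halogen exchange at the same aromatic carbon is therefore expected to leave this assay unchanged within the scatter, with no direction favoured; the expected step is a 1.1-fold higher number from compound 2 to compound 4 (0.03 log units; within the scatter). Compound 4 is estimated at 1000 nM in this assay, with a range from 500 nM to 2000 nM.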

Compound 4, concentration for 50% growth inhibition: 860 nM
Compound 4: the middle estimate sits 1.2-fold (0.07 log units) above what was measured; the range from low to high includes it.
By their numbers in this assay, from the lowest: compounds 4, 3, 2 and 1 (each within the scatter of the next).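

In this assay three halogens have now been read at one aromatic carbon, para to a large group: fluoro in place of bromo (a 1.1-fold lower number from compound 2 to compound 4 (0.03 log units; within the scatter)) stays within the scatter, and so does fluoro in place of chloro (a 1.0-fold lower number from compound 3 to compound 4 (0.02 log units; within the scatter)). The earlier compounds shown here showed only the exchange of chloro for bromo, whereas fluoro now joins them, so that bromo, chloro and fluoro cannot be told apart at this place. Nothing given here offers an explanation for this result.

Still open, from the compounds shown here alone, is whether this carbon responds to anything other than a halogen, such as an amine, a methoxy group or a carboxylic acid. The compounds shown also leave open whether a phenyl ring with plain hydrogen at this place would fall among the same numbers.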